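A few compounds are considered here, and "the series" means these few. Any claim that something is new, unique, unknown or untested is made for them only; others in the source may bear on it.

Measured compounds:
- compound 1 `COc1cc(-c2nnc(SCc3ccccc3)n2-c2ccc(N(C)C)cc2)cc(OC)c1OC`: 55800 nM
- compound 2 `COc1cc(-c2nnc(SCc3ccc(C)cc3)n2-c2ccc(N(C)C)cc2)cc(OC)c1OC`: 37300 nM

Both compounds share one core and differ only at the benzyl group on the sulfur. In a functional assay on PC-3 cells (Homo sapiens) for inhibition, read by MTT assay, with a stated time of 48 h (a higher number here means a weaker inhibitor, a lower number a stronger inhibitor), compound 1 gives 55800 nM, and compound 2 gives 37300 nM. Among the compounds with values here, the single step between them, a 1.5-fold lower number from compound 1 to compound 2 (0.17 log units; within the scatter), shows that a methyl in place of hydrogen on an aromatic carbon does not move the number beyond the scatter. Compound 2 therefore holds the lowest of the two numbers, yet this is not a meaningful separation from compound 1.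

Compound 3 `COc1ccc(C(=O)CSc2nnc(-c3cc(OC)c(OC)c(OC)c3)n2-c2ccc(N(C)C)cc2)cc1` has not been measured in this assay. It differs from compound 2 by (4-methoxyphenyl)carbonyl in place of 4-methylphenyl on a saturated chain carbon bound to a sulfur. Within the data shown here, no measured step concerns an exchange of this kind: the only step on record, between compound 1 and compound 2, touches a substituent on the aromatic ring and lies within the scatter, so it gives no direction for a change that replaces the whole 4-methylphenyl group. The expectation for compound 3 is therefore wide: a modest shift is estimated, a 1.5-fold lower number from compound 2 to compound 3 (0.17 log units; within the scatter), with no firm direction beyond the scatter. Compound 3 is estimated at 25000 nM, within a range from 7000 nM to 90000 nM.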

Compound 3, half-maximal inhibitory concentration: 22000 nM
Beside the measured number, compound 3's estimate is 1.1-fold (0.06 log units) above it; the measured number falls inside the stated range.
By their numbers in this assay, from the lowest: compounds 3, 2 and 1 (each within the scatter of the next, the first and the last beyond it).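

In this assay the saturated chain carbon bound to a sulfur tolerates the replacement of a whole 4-methylphenyl group, not just a methyl on its ring: the exchange for (4-methoxyphenyl)carbonyl gives a 1.7-fold lower number from compound 2 to compound 3 (0.23 log units; within the scatter), so this larger change also stays inside the scatter. Within the data shown here, measured against the plain phenyl at the same place, the exchange gives a 2.5-fold lower number from compound 1 to compound 3 (0.40 log units; beyond the scatter), the first step in this small set to pass beyond the scatter, though only modestly, and the methyl compound in the middle cannot be separated from either end. Nothing available on these compounds accounts for either step.

The carbonyl and the methoxy enter together, so the compounds shown leave open whether either alone, as in a plain phenylcarbonyl or a 4-methoxybenzyl group, would account for the step from the phenyl compound. They also leave open whether a carboxylic acid, an amine or a longer chain at this saturated chain carbon would move the number clearly beyond the scatter of all three compounds.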